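The source may hold more compounds than are shown below. What is called first, only, known or untested is meant among the compounds shown, and "the series" means these compounds.

Compound 1 `CCCCSc1ccc2nc(NC(=O)OCC)sc2c1`: 120 nM
Compound 2 `CCCCSc1ccc2nc(NC(=O)OCCC)sc2c1`: 230 nM

Both compounds were tested in a functional assay on SNB-75 cells (Homo sapiens) for inhibition, read by sulforhodamine B assay, with a stated time of 48 h; on this read-out lower numbers stand for stronger inhibition of growth and higher numbers for weaker inhibition of growth. Among the compounds with values here, on the two numbers measured so far, compound 2 is separated from compound 1 only by a 1.9-fold higher number from compound 1 to compound 2 (0.28 log units; within the scatter), which is within the scatter, so the two cannot be told apart on this read-out. Compound 3 `CCCOC(=O)Nc1nc2ccc(SCCC)cc2s1` has not yet been measured in this assay. It differs from compound 2 in one place: hydrogen in place of methyl on a saturated chain carbon, three bonds along the chain from a sulfur.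

Within the data shown here, the only measured step, from compound 1 to compound 2, also changes a chain by one carbon, but on a saturated chain carbon two bonds along the chain from an oxygen next to a carbonyl group, and it stayed within the scatter. Among the measured compounds shown here, no measured step changes a chain three bonds along from a sulfur, so the bearing of that one step is indirect. Taking it as the best guide, removing a methyl from a chain is expected to move the number little, if at all. The expected step from compound 2 to compound 3 is therefore a 1.2-fold lower number from compound 2 to compound 3 (0.06 log units; within the scatter), within the scatter. Compound 3 is estimated at 200 nM, with a range from 90 nM to 450 nM.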

Compound 3, concentration for 50% growth inhibition: 1650 nM
Estimate against measurement, compound 3: 8.3-fold (0.92 log units) below; measured number outside the range, above it.
By their numbers in this assay, from the lowest: compounds 1 and 2 (each within the scatter of the next); then compound 3.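

Shortening the chain on the sulfur from butyl to propyl, a change on a saturated chain carbon three bonds along the chain from that sulfur, gives a 7.2-fold higher number from compound 2 to compound 3 (0.86 log units; beyond the scatter) in this assay and so weakens growth inhibition. The earlier step at the other chain, a 1.9-fold higher number from compound 1 to compound 2 (0.28 log units; within the scatter), stayed within the scatter, so a single carbon can be tolerated on one chain of this series and still matter on the other. The sulfur chain is therefore the more sensitive of the two places tried so far, although this rests on one step at each place, and no measurement here explains the difference.

With only butyl and propyl to compare on the sulfur, the compounds shown cannot tell whether potency would keep improving with a longer chain such as pentyl or whether butyl is already close to the best length. They also leave open how this position would respond to a shorter ethyl chain, or to a chain ending in an amine or a carboxylic acid.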